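Thioether enones: bromophenyl sulfur substituent from compound 3

The source may hold more compounds than are shown below. What is called first, only, known or untested is meant among the compounds shown, and "the series" means these compounds.

Measured compounds in a functional assay on DU-145 cells (Homo sapiens) for inhibition, read by trypan blue exclusion, with a stated time of 96 h; on this read-out higher numbers stand for weaker inhibition of growth and lower numbers for stronger inhibition of growth:
compound 1 `O=C(/C(=C\c1ccc(O)cc1)SCc1ccc(Cl)cc1)c1ccc(Br)cc1` — 10000 nM
compound 2 `O=C(/C(=C\c1ccc(Cl)cc1)Sc1ccc(Br)cc1)c1ccc(Br)cc1` — 1000 nM
compound 3 `COc1ccc(/C=C(/SCc2ccc(Cl)cc2)C(=O)c2ccc(Br)cc2)cc1` — 10000 nM

Within this assay, compound 3 stands level with compound 1 at the digits shown, the two together the highest numbers of the set; compound 2 sits beyond the scatter below both. Within the data shown here, the only step that changes one place is no change at the digits printed from compound 1 to compound 3 (within the scatter); it reads as no change within the scatter.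

Compound 4 `COc1ccc(/C=C(/Sc2ccc(Br)cc2)C(=O)c2ccc(Br)cc2)cc1` has not yet been measured. It differs from compound 3 in one place: 4-bromophenyl in place of 4-chlorobenzyl on a sulfur. Among the measured compounds shown here, no measured step alters the group on sulfur while holding everything else fixed, so the change has no direct precedent. Compound 2 carries the same 4-bromophenyl on sulfur, but it also differs from compound 3 at the other aromatic ring, so its value bears on compound 4 only loosely. On that loose basis the number for compound 4 is expected to move toward that of compound 2, an estimated step of a 5.0-fold lower number from compound 3 to compound 4 (0.70 log units; beyond the scatter) in this assay. For compound 4 the estimate is 2000 nM, with a range from 700 nM to 7000 nM.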

Compound 4, concentration for 50% growth inhibition: 25000 nM
Compound 4: the middle estimate sits 13-fold (1.10 log units) below what was measured, and the stated range ends below it.
By their numbers in this assay, from the lowest: compound 2; then compounds 1 and 3 (each within the scatter of the next); then compound 4.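

In this assay, with the methoxy group held fixed, the change on the sulfur can now be read directly: 4-bromophenyl in place of 4-chlorobenzyl gives a 2.5-fold higher number from compound 3 to compound 4 (0.40 log units; beyond the scatter), so on this background the group brings weaker inhibition of growth, not the stronger inhibition seen with compound 2. The same 4-bromophenyl on sulfur also gives very different numbers depending on the group on the other aromatic ring: methoxy in place of chloro on an aromatic carbon gives a 25-fold higher number from compound 2 to compound 4 (1.40 log units; beyond the scatter), which ties the low number of compound 2 to the chloro group in this pair and not to the sulfur substituent alone. Nothing in hand accounts for either step.

Whether the change on sulfur runs in the same direction with chloro on the aromatic ring remains open: among the compounds shown, 4-chlorobenzyl on sulfur occurs only with hydroxy or methoxy there. Also open, as far as these compounds go, is how an amine or a carboxylic acid in place of chloro, or a longer chain on the sulfur, would read in this assay.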